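The source may hold more compounds than are shown below. What is called first, only, known or untested is meant among the compounds shown, and "the series" means these compounds.

Three compounds built on one shared core were tested in a functional assay on the whole organism (strain Wistar) with Rattus norvegicus as the target, with a stated time of 15 days, at a dose of 100 mg/kg by the oral route; a higher number here means a stronger effect of the compound at the dose given, a lower number a weaker effect. Compound 1 `O=C1NC(=O)/C(=C/c2ccc(OCCSc3nnc(-c4ccccc4)[nH]3)cc2)S1` gives 38.9%. Compound 2 `O=C1NC(=O)/C(=C/c2ccc(OCCSc3nnc(Cc4ccccc4)[nH]3)cc2)S1` gives 41.9%. Compound 3 `O=C1NC(=O)/C(=C/c2ccc(OCCSc3nnc(-c4ccccc4[N+](=O)[O-])[nH]3)cc2)S1` gives 49.1%. Among these three numbers compound 3 stands highest, but its nearest neighbour lies within the scatter, as a number 7.2 percentage points higher from compound 2 to compound 3 (within the scatter); only the gap to compound 1 is beyond it, since a number 10.2 percentage points higher from compound 1 to compound 3 (beyond the scatter). Compound 4 `O=C1NC(=O)/C(=C/c2ccc(OCCSc3nnc(-c4ccc(Cl)cc4)[nH]3)cc2)S1` has not yet been measured. It differs from compound 3 in one place: 4-chlorophenyl in place of 2-nitrophenyl on an aromatic carbon. Within the data shown here, the step that bears most on this is the one that put nitro in place of hydrogen, a number 10.2 percentage points higher from compound 1 to compound 3 (beyond the scatter), the only change among the three that went beyond the scatter; taking the nitro away again in compound 4 is therefore expected to give back some of that gain. Among the measured compounds shown here, the other two steps, a number 3 percentage points higher from compound 1 to compound 2 (within the scatter) and a number 7.2 percentage points higher from compound 2 to compound 3 (within the scatter), stayed within the scatter, and nothing among the measured compounds shows what a 4-chlorophenyl group does in this setting. For compound 4 a modest fall is expected, a number 7.1 percentage points lower from compound 3 to compound 4 (within the scatter), possibly still within the scatter. Compound 4 is therefore expected to give 42% in this assay, between 30% and 55%.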

Compound 4, a percentage reported as activity, at one dose (the size of the read-out at that dose, not a potency): 41.6%
Beside the measured number, compound 4's estimate is 0.4 percentage points above it, and the stated range covers the measured number.
By their numbers in this assay, from the lowest: compounds 1, 4, 2 and 3 (each within the scatter of the next, the first and the last beyond it).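

In this assay, chloro in place of hydrogen on the phenyl ring gives a step within the scatter, a number 2.7 percentage points higher from compound 1 to compound 4 (within the scatter) and so, unlike the nitro step a number 10.2 percentage points higher from compound 1 to compound 3 (beyond the scatter) that went beyond it, shows no clear effect of this substituent. Among these compounds, the direct exchange of the two substituted rings, a number 7.5 percentage points lower from compound 3 to compound 4 (within the scatter) and the exchange of benzyl for 4-chlorophenyl, a number 0.3 percentage points lower from compound 2 to compound 4 (within the scatter) also stay within the scatter, so the measured numbers cannot separate 4-chlorophenyl from 2-nitrophenyl, benzyl or phenyl on this aromatic carbon of the five-membered ring, and only the step from phenyl to 2-nitrophenyl is clear. Nothing measured here offers an explanation for these numbers.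

Nitro and chloro differ both as groups and in where they sit on the phenyl ring, so these compounds cannot show which of the two differences matters. On these data alone, it also remains open whether an amine or a carboxylic acid on that phenyl ring, or a longer chain in place of the benzyl link, would move the number beyond the scatter.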